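The source may report more compounds than this note shows. Statements on the series, on what has been measured and on what is new or still open speak of the compounds shown alone.

Series notes. Compound 1 `Cn1ncc(Cl)c1-c1cc(C(=O)NC2CNCCC2c2ccc(C(F)(F)F)cc2)oc1Cl`, compound 2 `Cn1ncc(Cl)c1-c1cc(C(=O)N[C@@H]2CN[C@H](CCN3CCCC3)C[C@H]2c2ccc(Cl)c(Cl)c2)oc1Cl` and compound 3 `Cn1ncc(Cl)c1-c1cc(C(=O)N[C@@H]2CN[C@H](CC(O)CO)C[C@H]2c2ccc(F)c(F)c2)oc1Cl` share one core and differ in the substitution on the saturated ring. In an assay for inhibition of RAC-alpha serine/threonine-protein kinase (Homo sapiens), read by HTRF, with a stated time of 1 h (on this read-out lower numbers stand for stronger inhibition and higher numbers for weaker inhibition), compound 1 gives 7.2 nM, compound 2 gives 6.41 nM and compound 3 gives 3.31 nM. Compound 2 thus holds the second highest of the three numbers; its nearest neighbour is compound 1 and its furthest is compound 3, and both gaps fall within the scatter, so no order among the three can be read from these numbers. The next compound, compound 4 `CNC(=O)C[C@@H]1C[C@@H](c2ccc(Cl)c(Cl)c2)[C@H](NC(=O)c2cc(-c3c(Cl)cnn3C)c(Cl)o2)CN1`, is compound 2 with a single change: methylcarbamoyl in place of (pyrrolidin-1-yl)methyl on a saturated chain carbon bound to a saturated ring carbon. Compound 3 already carries a different chain at this place and its number stays close to that of compound 2, which argues that this position tolerates such exchanges without a large shift. For compound 4 the step in this assay is expected to be small, a 1.1-fold lower number from compound 2 to compound 4 (0.03 log units; within the scatter), with no direction beyond the scatter. Compound 4 is therefore estimated at 6 nM, within 2 nM to 18 nM.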

Compound 4, half-maximal inhibitory concentration: 2.64 nM
For compound 4 the middle estimate is 2.3-fold (0.36 log units) above the measured one; the measured number falls inside the stated range.
By their numbers in this assay, from the lowest: compounds 4, 3, 2 and 1 (each within the scatter of the next, the first and the last beyond it).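

In this assay, methylcarbamoyl in place of (pyrrolidin-1-yl)methyl on a saturated chain carbon bound to a saturated ring carbon gives a 2.4-fold lower number from compound 2 to compound 4 (0.39 log units; beyond the scatter). Among the compounds shown here, this is the first single-place step, and it shows that the position does respond to an exchange, modestly, so the earlier impression of a position where such changes shift nothing no longer holds. The change removes a ring and brings in a hydrogen-bond donor and a double bond at once, and nothing measured here bears on why the number moves.

From the compounds shown here alone, it stays open whether the step follows the amide or the loss of the pyrrolidine ring: a dimethylamide or an open-chain dimethylamino group at this place would separate the two. A carboxylic acid or a longer chain carrying the methylcarbamoyl group would show how far the step extends.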